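The source may report more compounds than this note shows. Statements on the series, on what has been measured and on what is new or still open speak of the compounds shown alone.

Measured in a functional assay on A549 cells (Homo sapiens) for inhibition, read by sulforhodamine B assay, with a stated time of 48 h; on this read-out higher numbers stand for weaker inhibition of growth and lower numbers for stronger inhibition of growth:
- Compound 1 `COc1cc(/C=C/C(=O)/C(=C/c2cc(OC)c(OC)c(OC)c2)C(C)=O)cc(OC)c1OC`: 530 nM
- Compound 2 `COc1ccc(/C=C/C(=O)C(=Cc2ccc(O)c(OC)c2)C(=O)/C=C/c2ccc(OC)cc2)cc1`: 1640 nM
- Compound 3 `COc1ccc(/C=C/C(=O)C(=Cc2cc(OC)c(OC)c(OC)c2)C(=O)/C=C/c2ccc(OC)c(OC)c2)cc1OC`: 230 nM

Of these three, compound 3 gives the lowest number and so the strongest inhibition of growth. Its gaps to compound 1 and to compound 2 both lie beyond the usual scatter of repeated measurements, and the gap to compound 2 is the wider one.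

Compound 4 `COc1ccc(/C=C/C(=O)C(=Cc2cccc(F)c2)C(=O)/C=C/c2ccc(OC)c(OC)c2)cc1OC` has not yet been measured in this assay. It departs from compound 3 in one place: 3-fluorophenyl in place of 3,4,5-trimethoxyphenyl on a double-bonded chain carbon bound to a double-bonded chain carbon. In words, 3-fluorophenyl stands in place of 3,4,5-trimethoxyphenyl on a double-bonded chain carbon bound to a double-bonded chain carbon.

Going by the values given here, no pair of measured compounds differs by this change alone, so the evidence is indirect. Compound 1 at 530 nM and compound 3 at 230 nM both carry 3,4,5-trimethoxyphenyl, whereas compound 2 at 1640 nM lacks it, though compound 2 also differs elsewhere. On that slim hint, a moderate move towards weaker inhibition is expected, and the estimated step is a 3.0-fold higher number from compound 3 to compound 4 (0.48 log units; beyond the scatter).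

For compound 4 the estimated value is 700 nM, with an expected range from 220 nM to 2500 nM.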

Compound 4, concentration for 50% growth inhibition: 580 nM
Beside the measured number, compound 4's estimate is 1.2-fold (0.08 log units) above it; measured number inside the range.
By their numbers in this assay, from the lowest: compound 3; then compounds 1 and 4 (each within the scatter of the next); then compound 2.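

In this assay, this is the only step shown that changes the group at this position alone, on a double-bonded chain carbon bound to a double-bonded chain carbon. Replacing 3,4,5-trimethoxyphenyl with 3-fluorophenyl gives a 2.5-fold higher number from compound 3 to compound 4 (0.40 log units; beyond the scatter). This is a real but modest loss, so the full 3,4,5-trimethoxyphenyl group is not essential for growth inhibition in this series, even though the new group has fewer heavy atoms and 0 hydrogen-bond acceptors instead of 3. No measurement at hand explains the size of this step.

The compounds shown leave open which part of the change matters, since the methoxy groups leave and the fluorine enters in a single step; unsubstituted phenyl at this place would help to separate the two. On these data alone, it also remains open how a ring carrying an amine or a carboxylic acid would behave here, and whether the same swap would give a similar step on a different core.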